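Swapping Methyl for Trifluoromethyl on the Sulfur of Compound 1

A few compounds are considered here, and "the series" means these few. Any claim that something is new, unique, unknown or untested is made for them only; others in the source may bear on it.

Compound 1 `CSc1ccc(NC(=O)Nc2cc(C)nc3ccccc23)cc1` was examined in an ADME assay on BJ cells (Homo sapiens) for cytotoxicity, with a stated time of 72 h; a higher number here means that more compound is needed for the effect, a lower number that less compound is needed. In this assay compound 1 gives only a limit, > 25000 nM, so no exact number is known for it. This is the situation described by the limit of > 25000 nM in this assay, at which 1 of the 2 values shown sits. A second compound, compound 2 `COc1ccc(NC(=O)Nc2cc(C)nc3ccccc23)cc1F`, gives 26000 nM in this assay, a number at the high end of the range, meaning a large amount of compound is needed before the cells are affected. The two compounds are not compared as a step here, so only their two values stand side by side.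

Compound 3 `Cc1cc(NC(=O)Nc2ccc(SC(F)(F)F)cc2)c2ccccc2n1` has not yet been measured in this assay. It differs from compound 1 in one place: trifluoromethyl in place of methyl on a sulfur. Going by the values given here, no measured pair of compounds shares this change, so its effect is unknown. The step from compound 1 to compound 3 in this assay is expected to be small, an at least 1.2-fold lower number from compound 1 to compound 3 (0.09 log units; that floor lies within the scatter), with no clear direction beyond the scatter, given that compound 1 already sits at the limit. Compound 3 is therefore estimated at 20000 nM, within a range from 7000 nM to 40000 nM.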

Compound 3, half-maximal effective concentration: > 25000 nM
Compound 3 was reported as a limit (the forecaster's own chance of this, stated with the estimate: 50%); at least 1.2-fold (0.09 log units) between middle value and limit.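

In this assay, compound 1 and compound 3 each give only a limit and not an exact number, so no step can be read between them: the limit of > 25000 nM in this assay, at which 2 of the 3 values shown sit.

The compounds shown leave open whether trifluoromethyl in place of methyl on the sulfur changes the concentration needed for cytotoxicity at all, and in which direction.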